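Metabolic stability notes: pyrrolidin-1-yl for diethylamino

The source may hold more compounds than are shown below. What is called first, only, known or untested is meant among the compounds shown, and "the series" means these compounds.

Of the compounds shown here, two have numbers so far in an ADME assay on microsomes from liver (Rattus norvegicus, strain Sprague-Dawley) for metabolic stability, read by LC-MS, using NADPH, with a stated time of 60 min, tested at 10 mM; a higher number here means that more of the compound is left, a lower number that less of the compound is left. Compound 1 (`CN(C)CCCNc1nc(-c2[nH]c3ccccc3c2C=O)nc2ccccc12`) gives 71.1%. Compound 2 (`CCN(CC)CCCCNc1nc(-c2[nH]c3ccc(OC)cc3c2C=O)nc2ccccc12`) gives 84%, the higher of the two numbers, and its gap to compound 1 lies beyond the scatter. These two compounds differ in more than one place, so their gap is not tied to any single structural change.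

Compound 3 (`COc1ccc2[nH]c(-c3nc(NCCCCN4CCCC4)c4ccccc4n3)c(C=O)c2c1`) has not yet been measured in this assay. It departs from compound 2 in one place: pyrrolidin-1-yl in place of diethylamino on a saturated chain carbon, four bonds along the chain from a nitrogen on an aromatic ring. Pyrrolidin-1-yl thus takes the place of diethylamino on a saturated chain carbon, four bonds along the chain from a nitrogen on an aromatic ring. Going by the values given here, no measured pair shows this change on its own, so the expectation is weakly grounded.

The expected change is none beyond the scatter, with a slight downward lean, an estimated a number 4 percentage points lower from compound 2 to compound 3 (within the scatter). The lean rests on compound 2 at 84%, which has more room below than above on this scale. For compound 3 the estimated value is 80%, with an expected range of 66% to 92%.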

Compound 3, percent of the compound remaining: 80.7%
For compound 3 the middle estimate is 0.7 percentage points below the measured one; the range from low to high includes it.
By their numbers in this assay, from the lowest: compounds 1, 3 and 2 (each within the scatter of the next, the first and the last beyond it).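

In this assay, the series now has its first step that differs in one place: a number 3.3 percentage points lower from compound 2 to compound 3 (within the scatter), with pyrrolidin-1-yl in place of diethylamino on a saturated chain carbon, four bonds along the chain from a nitrogen on an aromatic ring. At this position, exchanging the open diethylamino for the ring of pyrrolidin-1-yl, with the same counts of heavy atoms and hydrogen-bond acceptors, gives no change in the percent of compound remaining that can be told from the scatter, so this single pair offers no reason to prefer either group on this read-out. Nothing at hand explains why the two groups read alike.

Going by these compounds, whether the same holds for piperidin-1-yl or morpholin-4-yl at this chain end, or for pyrrolidin-1-yl on a shorter or longer chain, remains open. Compound 1 differs from compound 2 and from compound 3 in more than one place, so its value gives no separate reading of the chain, the terminal amine or the other differences in the core.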